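Changing the Substituted Phenyl on the Amide Nitrogen

The compounds below may be only part of what the source reports. "The series", "measured", "known", "first", "only" and "open" are said of these compounds alone.

Measured compounds in a functional assay on MDA-MB-231 cells (Homo sapiens) for inhibition, read by MTT assay and WST assay, with a stated time of 72 h, tested at 10 uM; on this read-out higher numbers stand for more inhibition of growth at the one concentration tested and lower numbers for less inhibition of growth:
- compound 1 `Cc1ccc(NC(=O)Nc2ccc(Oc3ccc(-c4nccs4)cc3)cc2)cc1`; compound 1 gives 22.8%
- compound 2 `O=C(Nc1ccc(Oc2ccc(-c3nccs3)cc2)cc1)Nc1cc(C(F)(F)F)ccc1Cl`; compound 2 gives 60.4%

Compound 2 stands highest of these two numbers; its nearest neighbour is compound 1, and the step of a number 37.6 percentage points higher from compound 1 to compound 2 (beyond the scatter) lies beyond the scatter. Compound 3 `O=C(Nc1ccc(Oc2ccc(-c3nccs3)cc2)cc1)Nc1ccc(F)c(Cl)c1` has not yet been measured. It differs from compound 2 in one place: 3-chloro-4-fluorophenyl in place of 2-chloro-5-(trifluoromethyl)phenyl on an amide-type nitrogen. Within the data shown here, only one measured step bears on this change, the one from compound 1 to compound 2, which was large and rewarded a chlorine-and-trifluoromethyl-bearing phenyl over a methylphenyl. Compound 3 keeps a chlorine and adds a fluorine but gives up the trifluoromethyl, so a moderate fall in this assay is expected, estimated as a number 15.4 percentage points lower from compound 2 to compound 3 (beyond the scatter). For compound 3 the expected value is 45%, within a range from 25% to 65%.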

Compound 3, percent growth inhibition at one concentration: 43.9%
For compound 3 the middle estimate is 1.1 percentage points above the measured one; measured number inside the range.
By their numbers in this assay, from the lowest: compound 1; then compound 3; then compound 2.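

In this assay, putting 3-chloro-4-fluorophenyl in place of 2-chloro-5-(trifluoromethyl)phenyl gives a number 16.5 percentage points lower from compound 2 to compound 3 (beyond the scatter), so two phenyl groups that both carry a chlorine are not interchangeable on this amide-type nitrogen. The same 3-chloro-4-fluorophenyl group still gives a number 21.1 percentage points higher from compound 1 to compound 3 (beyond the scatter) when it replaces 4-methylphenyl, so among these three compounds the gain over 4-methylphenyl does not depend on having 2-chloro-5-(trifluoromethyl)phenyl, though that group gives the highest number. No measurement here explains why the three groups rank in this order.

Compound 2 and compound 3 differ both in where the chlorine sits and in trifluoromethyl against fluorine, so this step cannot be assigned to either change alone. Also open, as far as these compounds go, is how a phenyl carrying an amine or a carboxylic acid would compare on this nitrogen.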